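A Halogen Swap on the Triazole Aryl Group

This account rests on a few compounds, and the source may have more. Where it says the series, first, only, none or still open, it means among the compounds named here.

Compound 1 `COc1cc(O)c(C(=O)/C=C/c2ccc(OCc3cn(-c4ccc(Cl)cc4)nn3)c(OC)c2)c(OC)c1` sits at the assay ceiling in an ADME assay on Huh-7 cells (Homo sapiens) for cytotoxicity, read by MTT assay, with a stated time of 72 h (a lower number here means that less compound is tolerated, a higher number that more compound is tolerated), where compound 1 gives > 100 ug/mL, a limit rather than a number. Compound 3 `COc1cc(O)c(C(=O)/C=C/c2ccc(OCc3cn(-c4ccc(Cl)cc4)nn3)c(OCc3cn(-c4ccc(Cl)cc4)nn3)c2)c(OC)c1` in this assay also gives > 100 ug/mL, again a limit. Compound 2 `COc1cc(OC)c2c(=O)cc(-c3ccc(OCc4cn(-c5ccc(F)cc5Cl)nn4)c(OCc4cn(-c5ccc(F)cc5Cl)nn4)c3)oc2c1` in this assay likewise gives > 100 ug/mL, once more a limit. For the measured compounds named here, the single measured step, a step that the two limits leave unreadable from compound 1 to compound 3, cannot be read because of the limit of > 100 ug/mL in this assay, at which 3 of the 3 values shown sit. Compound 4 `COc1cc(O)c(C(=O)/C=C/c2ccc(OCc3cn(-c4ccc(F)cc4F)nn3)c(OC)c2)c(OC)c1` differs from compound 1 by 2,4-difluorophenyl in place of 4-chlorophenyl on an aromatic nitrogen. Going by the values given here, no measured step speaks to this change, and with every value resting at the ceiling, no shift beyond the scatter is expected. Compound 4 is therefore expected to give 150 ug/mL in this assay, with a range from 80 ug/mL to 300 ug/mL. The expected step that the limit leaves unreadable from compound 1 to compound 4 is thus estimated to be negligible.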

Compound 4, half-maximal cytotoxic concentration: > 100 ug/mL
Compound 4: only a limit was reported; the forecaster's own chance of this, stated with the estimate: 85%; the middle value lies beyond the limit too.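

No step can be read from compound 1 to compound 4, because both rest at a limit: the limit of > 100 ug/mL in this assay, at which 4 of the 4 values shown sit. The compounds shown leave open whether 2,4-difluorophenyl in place of 4-chlorophenyl changes tolerance at all.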